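The source may report more compounds than this note shows. Statements on the series, on what has been measured and on what is new or still open speak of the compounds shown alone.

Working notes on the series. Two compounds have numbers in a functional assay on NCI-H1299 cells (Homo sapiens) for inhibition, read by CCK-8 assay, with a stated time of 72 h, tested at 10 uM; a lower number here means a weaker effect, a higher number a stronger effect of the compound at the concentration tested. Compound 1 `CN(C)C(=O)c1cc2cnc(Nc3ccc(S(=O)(=O)NCCCCN=C=S)cc3)nc2n1C1CCCC1` gives 72.7% and stands highest of the two; compound 2 `CN(C)C(=O)c1cc2cnc(Nc3ccc(NC(=O)CCCCCCCN=C=S)cc3F)nc2n1C1CCCC1` gives 14%, a number well below it, beyond the scatter. Going by the values given here, compound 1 and compound 2 differ in more than one place, so no single step is read from them.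

Compound 3 `CN(C)C(=O)c1cc2cnc(Nc3ccc(N=C=S)cc3)nc2n1C1CCCC1` is still to be measured in this assay. Against compound 1 the change is a group of 3 heavy atoms (1 carbon, 1 nitrogen, 1 sulfur; no ring) in place of a group of 11 heavy atoms (5 carbon, 2 nitrogen, 2 oxygen, 2 sulfur; no ring), on an aromatic carbon, on an aromatic carbon of a six-membered aromatic ring of carbon only, para to a large group. Among the compounds with values here, no measured pair shows what the loss of the longer group does, so the expectation rests on the two numbers alone. For compound 3 the expected step is estimated as a number 32.7 percentage points lower from compound 1 to compound 3 (beyond the scatter), since compound 2 with the other chain gives 14%. Compound 3 is therefore estimated at 40%, within 10% to 72%.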

Compound 3, a percentage reported as inhibition, at one concentration (the size of the read-out at that concentration, not a potency): 83.7%
For compound 3 the middle estimate is 43.7 percentage points below the measured one, outside the stated range (above it).
By their numbers in this assay, from the lowest: compound 2; then compound 1; then compound 3.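

In this assay, the step for the group of 3 heavy atoms in place of the group of 11 heavy atoms, on an aromatic carbon para to a large group, is a number 11 percentage points higher from compound 1 to compound 3 (beyond the scatter). This position therefore does not need the longer group with its hydrogen-bond donor for a high number at the concentration tested, and the smaller group with no donor serves at least as well in this single pair. No measurement bears on why the number rises with this change.

The compounds shown leave open what an amine or a carboxylic acid on this same carbon would give, so the part played by the group of 3 heavy atoms itself cannot be separated from that of the shared core. Also open, from the compounds shown here alone, is how a short alkyl chain placed between the ring and this group would read.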